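This account rests on a few compounds, and the source may have more. Where it says the series, first, only, none or still open, it means among the compounds named here.

Measured compounds: compound 1 `CCCC/N=C(\NC#N)Nc1cccnc1` with 20 mg/kg; compound 2 `CC(C)C/N=C(\NC#N)Nc1cccnc1` with 20 mg/kg; compound 3 `CC(C)/N=C(\NC#N)Nc1cccnc1` with 2.5 mg/kg, all in a functional assay on the whole organism (blood, strain Wistar-Okamoto) with Rattus norvegicus as the target, with a stated time of 5 days; a lower number here means that less compound is needed, a higher number that more compound is needed for the effect.

Compound 3 has the lowest number of the three: an 8.0-fold lower number from compound 1 to compound 3 (0.90 log units; beyond the scatter) and an 8.0-fold lower number from compound 2 to compound 3 (0.90 log units; beyond the scatter), both beyond the scatter, while no change at the digits printed from compound 1 to compound 2 (within the scatter). Compound 4 `N#CN/C(=N\C1CC1)Nc1cccnc1` differs from compound 3 in one place: cyclopropyl in place of isopropyl on a double-bonded nitrogen. The two steps that bear on it, from compound 1 and from compound 2 to compound 3, show that shortening the chain to isopropyl lowers the number, and the step from compound 1 to compound 2 shows that reshaping a chain without shortening it changes nothing. For the measured compounds named here, no measured step closes a chain into a ring, so a step within the scatter is expected, no change at the digits printed from compound 3 to compound 4 (within the scatter). Compound 4 is estimated at 2.5 mg/kg, between 1 mg/kg and 6 mg/kg.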

Compound 4, minimum effective dose: 20 mg/kg
Compound 4: the middle estimate sits 8.0-fold (0.90 log units) below what was measured, outside the stated range (above it).
By their numbers in this assay, from the lowest: compound 3; then compounds 1, 2 and 4 (each within the scatter of the next).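

In this assay, tying isopropyl into a cyclopropyl ring on the double-bonded nitrogen, with the same count of heavy atoms, gives an 8.0-fold higher number from compound 3 to compound 4 (0.90 log units; beyond the scatter). Against the open chains, compound 4 shows no change at the digits printed from compound 2 to compound 4 (within the scatter) and no change at the digits printed from compound 1 to compound 4 (within the scatter), so among these four groups only the isopropyl of compound 3 stands apart. Nothing measured here offers a reason for this.

Open, going by these compounds, is whether methyl, ethyl, tert-butyl or a cyclobutyl ring at this place would share the low number of compound 3 or the higher one of the other three.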